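The source may hold more compounds than are shown below. What is called first, only, known or untested is meant among the compounds shown, and "the series" means these compounds.

Working notes on the series.

Compound 1 `COc1ccc(-n2c(=O)c(C(=O)Nc3ccc(Oc4ccnc5[nH]ccc45)c(F)c3)cc3cccnc32)cc1` and compound 2 `O=C(Nc1ccc(Oc2ccnc3[nH]ccc23)c(F)c1)c1cc2cccnc2n(-c2ccc(F)c(Cl)c2)c1=O` differ only at the aromatic nitrogen: 3-chloro-4-fluorophenyl in place of 4-methoxyphenyl on an aromatic nitrogen. In a functional assay on A549 cells (Homo sapiens) for antiproliferative activity, read by MTT assay, with a stated time of 72 h (a higher number here means a weaker inhibitor, a lower number a stronger inhibitor), compound 1 gives 610 nM and compound 2 gives 630 nM; the step of a 1.0-fold higher number from compound 1 to compound 2 (0.01 log units; within the scatter) shows the two sitting together.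

Compound 3 `COc1ccc(-n2c(=O)c(C(=O)Nc3ccc(Oc4ccnc5c4ccn5C)cc3)cc3cccnc32)cc1` gives 3460 nM in this assay, the highest number of the three measured compounds, with both gaps beyond the scatter. How its core differs from the core of compound 1 is not broken down here.

Compound 4 `Cn1ccc2c(Oc3ccc(NC(=O)c4cc5cccnc5n(-c5ccc(F)c(Cl)c5)c4=O)cc3)ccnc21` has not been measured. It relates to compound 3 as compound 2 relates to compound 1: 3-chloro-4-fluorophenyl in place of 4-methoxyphenyl on an aromatic nitrogen. The place lines of the two changes read the same word for word, so this is the same change, made on the core of compound 3.

The step from compound 3 to compound 4 in this assay is expected to be a 1.0-fold higher number from compound 3 to compound 4 (0.00 log units; within the scatter), because the same change gave a 1.0-fold higher number from compound 1 to compound 2 (0.01 log units; within the scatter). Among the measured compounds shown here, no further pair informs this change, so the expectation carries the scatter of a single pair. Compound 4 is expected at about 3500 nM in this assay, most plausibly between 1700 nM and 7000 nM.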

Compound 4, half-maximal inhibitory concentration: 820 nM
For compound 4 the middle estimate is 4.3-fold (0.63 log units) above the measured one; measured number below the stated range.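

In this assay, 3-chloro-4-fluorophenyl in place of 4-methoxyphenyl on the aromatic nitrogen gives a 4.2-fold lower number from compound 3 to compound 4 (0.63 log units; beyond the scatter), so the size of this step cannot be carried unchanged from one core to the other: the same change on two cores in this assay, a 1.0-fold higher number (0.01 log units; within the scatter) from compound 1 to compound 2 and a 4.2-fold lower number (0.63 log units; beyond the scatter) from compound 3 to compound 4, 4.4-fold (0.64 log units) apart, beyond the scatter of two such steps

The comparison rests on a single pair for each of two cores, and it shows that the step depends on the core within these four compounds, not how it would behave on any further core. The core of compound 1 and the core of compound 3 differ in more than one place, and the compounds shown do not tell which of those differences goes with the change in the step, nor give any reason for it.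

Open, going by these compounds, is whether the step seen on the core of compound 3 would persist on a core that carries only one of those differences. Also open, on these data alone, is how other groups on the aromatic nitrogen, such as a plain alkyl chain or a phenyl ring bearing an amine or a carboxylic acid, would behave on either core.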